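The source may report more compounds than this note shows. Statements on the series, on what has been measured and on what is new or still open speak of the compounds shown alone.

Of the compounds shown here, three that share a core have been measured in a functional assay on HT-29 cells (Homo sapiens) for inhibition, read by sulforhodamine B assay, with a stated time of 72 h; on this read-out lower numbers stand for stronger inhibition and higher numbers for weaker inhibition. Compound 1 `COc1cc(N2C(=O)CC2c2ccc(SC)cc2)cc(OC)c1OC` gives 108 nM, and compound 2 `C=CC1C(=O)N(c2cc(OC)c(OC)c(OC)c2)C1c1ccc(SC)cc1` gives 113 nM, so the step is a 1.0-fold higher number from compound 1 to compound 2 (0.02 log units; within the scatter). Compound 3 `COc1ccc(C2C(Oc3ccccc3)C(=O)N2c2cc(OC)c(OC)c(OC)c2)cc1` gives 52 nM, the lowest of the three numbers, and its gap to each of the other two lies just beyond the scatter. It differs from them in more than one place, so that gap cannot be traced to any single change.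

Compound 4 `COc1cc(N2C(=O)C(Oc3ccccc3)C2c2ccc(SC)cc2)cc(OC)c1OC` is compound 3 with one change: methylsulfanyl in place of methoxy on an aromatic carbon. Methylsulfanyl takes the place of methoxy on an aromatic carbon, turning 4-methoxyphenyl into 4-(methylsulfanyl)phenyl.

Going by the values given here, no measured step makes this swap. Among the compounds with values here, the only single-place step, a 1.0-fold higher number from compound 1 to compound 2 (0.02 log units; within the scatter), is a vinyl in place of hydrogen on a saturated ring carbon, and both of its compounds already carry methylsulfanyl. It therefore offers only weak guidance. The higher numbers of those two methylsulfanyl compounds hint that any shift would be upward, but nothing isolates the swap itself.

In this assay, the expected result is no step beyond the scatter, estimated as a 1.2-fold higher number from compound 3 to compound 4 (0.06 log units; within the scatter). Compound 4 is estimated at 60 nM, with an expected range from 20 nM to 180 nM.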

Compound 4, half-maximal inhibitory concentration: 336 nM
The estimate for compound 4 lay 5.6-fold (0.75 log units) below the measured number; the whole stated range lies below it.
By their numbers in this assay, from the lowest: compound 3; then compounds 1 and 2 (each within the scatter of the next); then compound 4.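

In this assay, putting sulfur where oxygen stood in this group on the aromatic ring is far from a neutral swap: methylsulfanyl in place of methoxy gives a 6.5-fold higher number from compound 3 to compound 4 (0.81 log units; beyond the scatter) with phenoxy present on the saturated ring carbon. That saturated ring carbon also proves sensitive to what it carries when methylsulfanyl is fixed, since phenoxy gives a 3.1-fold higher number from compound 1 to compound 4 (0.49 log units; beyond the scatter) in place of hydrogen and a 3.0-fold higher number from compound 2 to compound 4 (0.47 log units; beyond the scatter) in place of vinyl, whereas vinyl in place of hydrogen gave only a 1.0-fold higher number from compound 1 to compound 2 (0.02 log units; within the scatter) and stayed level. No measurement at hand accounts for any of these steps.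

The compounds shown include no methoxy partner for compound 1 or compound 2, so it remains open whether the swap carries the same penalty when hydrogen or vinyl sits on the saturated ring carbon rather than phenoxy. Going by these compounds, it is also open how a hydroxyl group, an amine or a longer chain such as ethoxy would fare on the same aromatic carbon, and so whether methoxy is specifically favoured there or methylsulfanyl specifically disfavoured.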